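The source may report more compounds than this note shows. Statements on the series, on what has been measured and on what is new or still open speak of the compounds shown alone.

Four compounds share one core and differ at two places. Compound 1 `C/C=C/C(=O)Nc1cc2c(N3CCc4ccccc43)ncnc2cc1O[C@@H]1CCOC1` carries a (prop-1-en-1-yl)carbonyl group and a 2,3-dihydro-1H-indol-1-yl group. In a functional assay on A549 cells (Homo sapiens) for antiproliferative activity, read by MTT assay, with a stated time of 72 h (on this read-out lower numbers stand for stronger inhibition and higher numbers for weaker inhibition), compound 1 gives 2610 nM. Compound 2 `CC/C=C/C(=O)Nc1cc2c(N3CCc4ccccc43)ncnc2cc1O[C@@H]1CCOC1` differs from compound 1 by methyl in place of hydrogen on a saturated chain carbon bound to a double-bonded chain carbon. In this assay compound 2 gives 10900 nM, and that step is a 4.2-fold higher number from compound 1 to compound 2 (0.62 log units; beyond the scatter). Compound 3 `C/C=C/C(=O)Nc1cc2c(N3CCCc4ccccc43)ncnc2cc1O[C@@H]1CCOC1` differs from compound 1 by 1,2,3,4-tetrahydroquinolin-1-yl in place of 2,3-dihydro-1H-indol-1-yl on an aromatic carbon. In this assay compound 3 gives 10800 nM, and that step is a 4.1-fold higher number from compound 1 to compound 3 (0.62 log units; beyond the scatter). Compound 4 `CC/C=C/C(=O)Nc1cc2c(N3CCCc4ccccc43)ncnc2cc1O[C@@H]1CCOC1` has not yet been measured in this assay. Within the data shown here, it differs from compound 3 by methyl in place of hydrogen on a saturated chain carbon bound to a double-bonded chain carbon, which is the same change, at the same place, as the one from compound 1 to compound 2. Because that change gave a 4.2-fold higher number from compound 1 to compound 2 (0.62 log units; beyond the scatter), a higher number of similar size is expected here, though compound 3 carries the other core and a single earlier step is a thin basis. For compound 4 the expected step is a 3.7-fold higher number from compound 3 to compound 4 (0.57 log units; beyond the scatter). Compound 4 is estimated at 40000 nM, with a range from 15000 nM to 110000 nM.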

Compound 4, half-maximal inhibitory concentration: 14100 nM
For compound 4 the middle estimate is 2.8-fold (0.45 log units) above the measured one; the measured number lies below the stated range.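

In this assay, the change from (prop-1-en-1-yl)carbonyl to (but-1-en-1-yl)carbonyl gives a 1.3-fold higher number from compound 3 to compound 4 (0.12 log units; within the scatter), so the size of its effect does not carry over from one core to the other: the same change on two cores in this assay, a 4.2-fold higher number (0.62 log units; beyond the scatter) from compound 1 to compound 2 and a 1.3-fold higher number (0.12 log units; within the scatter) from compound 3 to compound 4, 3.2-fold (0.50 log units) apart, beyond the scatter of two such steps The change from 2,3-dihydro-1H-indol-1-yl to 1,2,3,4-tetrahydroquinolin-1-yl behaves the same way, giving a 1.3-fold higher number from compound 2 to compound 4 (0.11 log units; within the scatter), so its effect also depends on what stands at the other place: the same change on two cores in this assay, a 4.1-fold higher number (0.62 log units; beyond the scatter) from compound 1 to compound 3 and a 1.3-fold higher number (0.11 log units; within the scatter) from compound 2 to compound 4, 3.2-fold (0.50 log units) apart, beyond the scatter of two such steps Each change alone raises the number beyond the scatter, yet with one already present the other adds no step beyond the scatter; this rests on just four compounds and does not show why the two changes fail to add up, or whether the same holds on any other core.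

Going by these compounds, it remains open whether a longer chain than but-1-en-1-yl, or an amine on that chain, would follow the same pattern. It is also open how a group such as morpholin-4-yl in place of the two ring groups shown would fit it.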